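Moving the Fluorine on the Aryl Group of Compound 1

The source may report more compounds than this note shows. Statements on the series, on what has been measured and on what is new or still open speak of the compounds shown alone.

Among the measured compounds shown here, compound 1 `CC(C)OC(=O)N1CCC(Oc2ncnc3c2CCN3c2ccc(S(C)(=O)=O)cc2F)CC1` is one of two compounds measured in a functional assay on CHO-K1 cells with Glucose-dependent insulinotropic receptor (Homo sapiens) as the target, read by a luciferase reporter, with a stated time of 5 h (on this read-out higher numbers stand for larger maximal responses and lower numbers for smaller maximal responses), and compound 1 gives 91%, the lower of the two numbers. Its neighbour compound 2 `CC(C)COC(=O)N1CCC(Oc2ncnc3c2CCN3c2ccc(S(C)(=O)=O)cc2F)CC1` gives 94%, and the step of a number 3 percentage points higher from compound 1 to compound 2 (within the scatter) lies within the scatter. Compound 3 `CC(C)OC(=O)N1CCC(Oc2ncnc3c2CCN3c2ccc(S(C)(=O)=O)c(F)c2)CC1` differs from compound 1 by 3-fluoro-4-(methylsulfonyl)phenyl in place of 2-fluoro-4-(methylsulfonyl)phenyl on a nitrogen on an aromatic ring in a ring. For the measured compounds named here, no measured step touches this part of the structure; the one measured step concerns the carbamate and stays within the scatter. One therefore expects no step beyond the scatter in this assay, estimating a number 3 percentage points lower from compound 1 to compound 3 (within the scatter). Compound 3 is expected to reach 88%, between 70% and 102%.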

Compound 3, largest response reached (reported as percent of maximum), in percent of the reference or control that the assay uses: 109%
Beside the measured number, compound 3's estimate is 21 percentage points below it; measured number outside the range, above it.
By their numbers in this assay, from the lowest: compounds 1 and 2 (each within the scatter of the next); then compound 3.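

Exchanging 2-fluoro-4-(methylsulfonyl)phenyl for 3-fluoro-4-(methylsulfonyl)phenyl, with the same atoms joined differently, gives in this assay a number 18 percentage points higher from compound 1 to compound 3 (beyond the scatter). The aryl group on the nitrogen is therefore a place where the maximal response can shift, which the carbamate change, a number 3 percentage points higher from compound 1 to compound 2 (within the scatter), did not show. No available evidence bears on the reason for this step. Going by these compounds, whether the isobutyl carbamate of compound 2 keeps this gain with the 3-fluoro-4-(methylsulfonyl)phenyl group remains open. So does the effect of a nitrile or chlorine in place of this fluorine.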